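The source may hold more compounds than are shown below. What is called first, only, known or untested is meant among the compounds shown, and "the series" means these compounds.

Assay: an assay on isolated protein for binding affinity to secreted frizzled-related protein 1 (Homo sapiens), read by fluorescence; on this read-out lower numbers stand for stronger inhibition and higher numbers for weaker inhibition.

Compound 1 `O=C(CN1CCNCC1)N1CCC(NS(=O)(=O)c2cc(S(=O)(=O)c3ccccc3)ccc2C(F)(F)F)CC1` gives 140 nM.
Compound 2 `CC(C)C(=O)N1CCC[C@H]1C(=O)N1CCC(NS(=O)(=O)c2cc(S(=O)(=O)c3ccccc3)ccc2C(F)(F)F)CC1` gives 40 nM.
Compound 3 `CC(C)(C)CC(=O)N1CCC[C@H]1C(=O)N1CCC(NS(=O)(=O)c2cc(S(=O)(=O)c3ccccc3)ccc2C(F)(F)F)CC1` gives 20 nM.

Compound 3 carries the lowest number of the three. Its gap to compound 2, a 2.0-fold lower number from compound 2 to compound 3 (0.30 log units; within the scatter), is within the scatter, so the two cannot be ranked against each other; its gap to compound 1, a 7.0-fold lower number from compound 1 to compound 3 (0.85 log units; beyond the scatter), is beyond it, as is a 3.5-fold lower number from compound 1 to compound 2 (0.54 log units; beyond the scatter). The whole gain in the series therefore comes from the exchange of the (piperazin-1-yl)methyl group for the acylated pyrrolidine, while the alkyl group on the outer carbonyl carbon has so far made little difference.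

Compound 4 `CC(C)(C)NC(=O)N1CCC[C@H]1C(=O)N1CCC(NS(=O)(=O)c2cc(S(=O)(=O)c3ccccc3)ccc2C(F)(F)F)CC1` differs from compound 3 in (tert-butyl)amino in place of neopentyl on a carbonyl carbon. Among the measured compounds shown here, the only measured step at this position, a 2.0-fold lower number from compound 2 to compound 3 (0.30 log units; within the scatter), exchanged one alkyl group for another and stayed within the scatter. For the measured compounds named here, no measured step replaces a carbon by a nitrogen bearing a hydrogen-bond donor on this carbonyl carbon, so the effect of the urea-type linkage is untested here. On the evidence of a 2.0-fold lower number from compound 2 to compound 3 (0.30 log units; within the scatter), no step beyond the scatter is expected in this assay, with a slight lean towards a higher number. Compound 4 is expected to give 30 nM, range 12 nM to 80 nM. The expected step is a 1.5-fold higher number from compound 3 to compound 4 (0.18 log units; within the scatter).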

Compound 4, half-maximal inhibitory concentration: 20 nM
The estimate for compound 4 lay 1.5-fold (0.18 log units) above the measured number, and the stated range covers the measured number.
By their numbers in this assay, from the lowest: compounds 3, 4 and 2 (each within the scatter of the next); then compound 1.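

In this assay, among the compounds shown here, (tert-butyl)amino in place of neopentyl is the first exchange on this carbonyl carbon that brings in a nitrogen and a hydrogen-bond donor, and it leaves the reading flat (no change at the digits printed from compound 3 to compound 4 (within the scatter)), so the donor is tolerated here as far as this read-out can tell. The comparison with the isopropyl compound also stays within the scatter (a 2.0-fold lower number from compound 2 to compound 4 (0.30 log units; within the scatter)), which leaves compounds 2, 3 and 4 unranked and extends the insensitivity of this position from alkyl groups to the (tert-butyl)carbamoyl group, while the gain over the (piperazin-1-yl)methyl compound survives the exchange (a 7.0-fold lower number from compound 1 to compound 4 (0.85 log units; beyond the scatter)). No measurement at hand speaks to how the hydrogen-bond donor is accommodated at this position.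

Still open, on these data alone, is whether this flat response extends to groups of a different kind on the same carbonyl carbon, such as a carboxylic acid or a primary amine at the end of a longer chain, or a phenyl ring. Also open, as far as these compounds go, is whether the amide hydrogen of the (tert-butyl)amino group can be replaced by a methyl group with the reading held.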